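The compounds below may be only part of what the source reports. "The series", "measured", "known", "first", "only" and "open" are said of these compounds alone.

Compound 1 `CC(=O)N(C)c1ccc2[nH]c(-c3n[nH]c4ccccc34)cc2n1` gives 5110 nM in a functional assay on HL-60 cells (Homo sapiens) for antiproliferative activity, read by MTT assay, with a stated time of 72 h; a higher number here means a weaker inhibitor, a lower number a stronger inhibitor.
Compound 2 `CN(C(=O)c1ccccc1)c1ccc2[nH]c(-c3n[nH]c4ccccc34)cc2n1` gives 4850 nM.
Compound 3 `CN(C(=O)c1ccc(F)cc1)c1ccc2[nH]c(-c3n[nH]c4ccccc34)cc2n1` gives 1210 nM.

Compound 3 has the lowest number of the three, and both steps toward it, a 4.2-fold lower number from compound 1 to compound 3 (0.63 log units; beyond the scatter) and a 4.0-fold lower number from compound 2 to compound 3 (0.60 log units; beyond the scatter), lie beyond the scatter, so it is the strongest inhibitor measured here. By contrast, the step of a 1.1-fold lower number from compound 1 to compound 2 (0.02 log units; within the scatter) stays within the scatter.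

Compound 4 `CN(C(=O)c1ccc([N+](=O)[O-])cc1)c1ccc2[nH]c(-c3n[nH]c4ccccc34)cc2n1` differs from compound 3 in one place: nitro in place of fluoro on an aromatic carbon. The step that bears most on this is a 4.0-fold lower number from compound 2 to compound 3 (0.60 log units; beyond the scatter), which shows that a change at this place can move the number modestly. Among the compounds with values here, no measured compound carries a nitro group, so the direction is not fixed by the data. The step of a 1.1-fold lower number from compound 3 to compound 4 (0.04 log units; within the scatter) is therefore expected to stay within the scatter. Compound 4 is estimated at 1100 nM, with a range from 300 nM to 4000 nM.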

Compound 4, half-maximal inhibitory concentration: 6800 nM
For compound 4 the middle estimate is 6.2-fold (0.79 log units) below the measured one; the measured number lies above the stated range.
By their numbers in this assay, from the lowest: compound 3; then compounds 2, 1 and 4 (each within the scatter of the next).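

At this carbon of the aromatic ring, the lower number seen with fluoro does not carry over to nitro (a 5.6-fold higher number from compound 3 to compound 4 (0.75 log units; beyond the scatter)), so the identity of the group matters and not just the presence of one. Nitro instead stays level with hydrogen at this place (a 1.4-fold higher number from compound 2 to compound 4 (0.15 log units; within the scatter)) and with methyl on the carbonyl carbon (a 1.3-fold higher number from compound 1 to compound 4 (0.12 log units; within the scatter)), which leaves fluoro alone among these groups in lowering the number. Nothing measured here explains why fluoro and nitro differ. Still open, going by these compounds, is whether chloro, methoxy or an amine at this place would behave like fluoro or like nitro.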